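A Ring Swap at the Thiocarbonyl Carbon

The source may hold more compounds than are shown below. What is called first, only, known or untested is meant among the compounds shown, and "the series" means these compounds.

Three compounds have been measured in a functional assay on MCF7 cells (Homo sapiens) for cytotoxicity, read by MTT assay, with a stated time of 72 h, tested at 10 uM; a higher number here means more inhibition of growth at the concentration tested, a lower number less inhibition of growth:

Compound 1, `N/C(=N\NC(=S)N1CCCCCC1)c1ccccn1`, gives 62.2%.
Compound 2, `N/C(=N\NC(=S)N1CCN(c2ccccn2)CC1)c1ccc(F)cn1`, gives 35.8%.
Compound 3, `N/C(=N\NC(=S)N1CCCC1)c1ccc(F)cn1`, gives 54.5%.

Compound 3 stands second highest of the three numbers. Its nearest neighbour is compound 1, whose number is higher by an amount that falls within the usual scatter, so the two cannot be told apart. Its furthest neighbour is compound 2, whose number is lower by an amount beyond the scatter; what sets compound 2 apart structurally is not a single change, so nothing more can be drawn from that pair.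

Compound 4, `N/C(=N\NC(=S)N1CCSCC1)c1ccc(F)cn1`, has not yet been measured. It differs from compound 3 in one place: thiomorpholin-4-yl in place of pyrrolidin-1-yl on a thiocarbonyl carbon. For the measured compounds named here, no pair of measured compounds differs in only this kind of ring, so there is no measured step to lean on. In this assay the expected step is a number 4.5 percentage points lower from compound 3 to compound 4 (within the scatter), a small lean downward that stays within the scatter. On that basis compound 4 is estimated to give 50%, within a range from 32% to 68%.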

Compound 4, percent growth inhibition at one concentration: 38.1%
Compound 4: middle estimate off by 11.9 percentage points, on the high side; low and high end bracket the measured number.
By their numbers in this assay, from the lowest: compounds 2 and 4 (each within the scatter of the next); then compounds 3 and 1 (each within the scatter of the next).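

In this assay, for the compounds shown here, the swap of pyrrolidin-1-yl for thiomorpholin-4-yl gives a number 16.4 percentage points lower from compound 3 to compound 4 (beyond the scatter) and is the first single change that can be read in this set. The ring on the thiocarbonyl carbon therefore matters for this read-out: with the rest of the molecule held the same, replacing one non-aromatic ring with the other moves the number by more than the usual scatter. The swap alters ring size and adds a sulfur atom at once, and nothing measured here accounts for the lower number or shows which of those two differences goes with it.

The compounds shown leave open whether ring size or the sulfur atom goes with the step, a question that piperidin-1-yl, a six-membered ring without sulfur, or morpholin-4-yl, which carries oxygen where thiomorpholin-4-yl carries sulfur, could help to separate. Going by these compounds, it also remains open whether the same swap would give a step of similar size on the core of compound 1, which lacks the fluorine.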